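Replacing the dichlorophenyl sulfone in a glutamate receptor series

This account rests on a few compounds, and the source may have more. Where it says the series, first, only, none or still open, it means among the compounds named here.

Measured so far in an assay on isolated protein for displacement of a labelled ligand from metabotropic glutamate receptor 5 (Homo sapiens), with a stated time of 60 min, tested at 1 uM; on this read-out lower numbers stand for less inhibition and higher numbers for more inhibition at the one concentration tested (going by the name of the read-out):
- compound 1 `CC1CCN(c2c(S(=O)(=O)c3cc(Cl)cc(Cl)c3)cnc3ccc(Cl)cc23)CC1`: 88%
- compound 2 `CC1CCN(c2c(S(=O)(=O)c3cc(Cl)cc(Cl)c3)cnc3ccc(F)cc23)CC1`: 69%
- compound 3 `Cc1ccc2ncc(S(=O)(=O)c3cc(Cl)cc(Cl)c3)c(N3CCC(C)CC3)c2c1`: 75%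

Compound 3 stands second highest of the three; compound 2 lies within the scatter of it, while compound 1 is higher by a number 13 percentage points lower from compound 1 to compound 3 (beyond the scatter). Compound 4 `Cc1ccc2ncc(S(=O)(=O)c3ccc(C)c(C)c3)c(N3CCC(C)CC3)c2c1` differs from compound 3 by 3,4-dimethylphenyl in place of 3,5-dichlorophenyl on a sulfonyl sulfur. Among the compounds with values here, no measured step touches this part of the molecule; the steps measured so far all change a group on the shared core, and the nearest parallel is the methyl in place of chloro on an aromatic carbon that gave a number 13 percentage points lower from compound 1 to compound 3 (beyond the scatter). On that weak analogy a modest drop is expected, with compound 4 estimated at 60% (range 35% to 80%), a step of a number 15 percentage points lower from compound 3 to compound 4 (beyond the scatter) expected from the change.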

Compound 4, a percentage reported as inhibition, at one concentration (the size of the read-out at that concentration, not a potency): 90%
The estimate for compound 4 lay 30 percentage points below the measured number; measured number outside the range, above it.
By their numbers in this assay, from the lowest: compounds 2 and 3 (each within the scatter of the next); then compounds 1 and 4 (each within the scatter of the next).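

In this assay, within the data shown here, the aryl group on the sulfonyl sulfur proves to matter as well, whereas the earlier steps changed only a group on the shared core. Putting 3,4-dimethylphenyl in place of 3,5-dichlorophenyl gives a number 15 percentage points higher from compound 3 to compound 4 (beyond the scatter), so for this pair the chlorines are not needed to keep the inhibition at the one concentration tested. No measurement here accounts for the rise.

As far as these compounds go, whether a single methyl, a methoxy group or a pyridine ring would serve on the sulfonyl sulfur stays open. So does whether 3,4-dimethylphenyl gives a similar step with chloro or fluoro on the core.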